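Methyl in Place of Chloro on Compound 1

A few compounds are considered here, and "the series" means these few. Any claim that something is new, unique, unknown or untested is made for them only; others in the source may bear on it.

Compound 1 `Nc1c(C(=O)N/N=C/c2ccc(Cl)cc2)oc2nc(-c3cccs3)cc(C(F)(F)F)c12` gives 83000 nM in an ADME assay on HEK293 cells (Homo sapiens) for antiproliferative activity, read by MTT assay (on this read-out higher numbers stand for weaker inhibition and lower numbers for stronger inhibition), the highest of the three numbers in this set, though compound 2 `CCCNC(=O)c1oc2nc(-c3ccccc3)cc(C(F)(F)F)c2c1N` with 81000 nM and compound 3 `Nc1c(C(=O)N/N=C/c2ccc(Br)cc2)oc2nc(-c3ccccc3)cc(C(F)(F)F)c12` with 64000 nM both lie within the scatter of it. Compound 4 `Cc1ccc(/C=N/NC(=O)c2oc3nc(-c4cccs4)cc(C(F)(F)F)c3c2N)cc1` differs from compound 1 by methyl in place of chloro on an aromatic carbon. No measured step touches that position; the only step shown, a 1.3-fold lower number from compound 2 to compound 3 (0.10 log units; within the scatter), exchanges a much larger group on an amide-type nitrogen and still stays within the scatter. With nothing bearing directly on this exchange and all three numbers close together, the step is expected to be a 1.0-fold higher number from compound 1 to compound 4 (0.01 log units; within the scatter), nothing beyond the scatter. The estimate for compound 4 is 85000 nM, between 40000 nM and 180000 nM.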

Compound 4, half-maximal inhibitory concentration: 78000 nM
Compound 4: middle estimate off by 1.1-fold (0.04 log units), on the high side; low and high end bracket the measured number.
By their numbers in this assay, from the lowest: compounds 3, 4, 2 and 1 (each within the scatter of the next).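

In this assay, for the compounds shown here, methyl in place of chloro gives a 1.1-fold lower number from compound 1 to compound 4 (0.03 log units; within the scatter) and so provides the first direct step at this aromatic carbon. On this core, the change from 4-chlorophenyl to 4-methylphenyl leaves the number within the scatter. No supporting measurement bears on this result. From the compounds shown here alone, whether an amine, a carboxylic acid or a longer chain on this aromatic carbon would move the number beyond the scatter remains open. So does whether methyl in place of bromo on compound 3 would also stay within it.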